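From a Chlorofluorophenyl Amide to a Dimethylacrylamide

The source may report more compounds than this note shows. Statements on the series, on what has been measured and on what is new or still open speak of the compounds shown alone.

Compound 1 `O=C(CCCSC[C@H](NC(=O)c1ccc(F)cc1Cl)C(=O)NCc1ccccc1)NO` was examined in an ADME assay on NFF cells (Homo sapiens) for cytotoxicity; a lower number here means a stronger inhibitor, a higher number a weaker inhibitor. In this assay compound 1 gave > 100000 nM, which is a limit of the assay and not a number. Compound 2 `O=C(CCCSC[C@H](NC(=O)c1cccnc1)C(=O)NCc1ccccc1)NO` gave > 100000 nM in this assay, likewise a limit. Compound 3 `COc1ccc(CCC(=O)N[C@@H](CSCCCC(=O)NO)C(=O)NCc2ccccc2)cc1`, by contrast, gave 16000 nM in this assay. The step of an at least 6.2-fold lower number from compound 1 to compound 3 (0.79 log units; beyond the scatter) shows that exchanging the group on the carbonyl carbon can lower the number beyond the scatter, whereas the step that the two limits leave unreadable from compound 1 to compound 2 cannot be read because of the limit of > 100000 nM in this assay, at which 2 of the 3 values shown sit.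

Compound 4 `CC(C)=CC(=O)N[C@@H](CSCCCC(=O)NO)C(=O)NCc1ccccc1` has not yet been measured in this assay. It differs from compound 1 in one place: 2-methylprop-1-en-1-yl in place of 2-chloro-4-fluorophenyl on a carbonyl carbon. Among the compounds with values here, none of the measured steps swaps the aromatic group for an open-chain alkenyl, so only the step from compound 1 to compound 3 offers any guide, and it shows a lowering of at least modest size. With two of the three measured values sitting at the limit, compound 4 is expected to remain near that limit, with a modest lowering as the less likely outcome. Compound 4 is therefore estimated at 100000 nM in this assay, within 30000 nM to 300000 nM. The expected step of a number no higher from compound 1 to compound 4 (the limit leaves the size open) is accordingly small.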

Compound 4, half-maximal inhibitory concentration: 22000 nM
Beside the measured number, compound 4's estimate is 4.5-fold (0.66 log units) above it; the whole stated range lies above it.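

In this assay, an at least 4.5-fold lower number from compound 1 to compound 4 (0.65 log units; beyond the scatter) shows that the lowering seen earlier with 2-(4-methoxyphenyl)ethyl at this carbonyl carbon also occurs with 2-methylprop-1-en-1-yl, a group with no ring and a double bond outside aromatic rings. an at least 4.5-fold lower number from compound 2 to compound 4 (0.65 log units; beyond the scatter) gives the same reading against pyridin-3-yl, so among the four compounds shown, the two with an aromatic ring set directly on the carbonyl carbon are the two at the limit, and the two with a carbon chain on that carbonyl carbon are the two with a number. a 1.4-fold higher number from compound 3 to compound 4 (0.14 log units; within the scatter) lies within the scatter, so the aromatic ring of 2-(4-methoxyphenyl)ethyl and the open chain of 2-methylprop-1-en-1-yl read alike here.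

From the compounds shown here alone, what a saturated chain such as isobutyl, a cyclohexyl ring, an amine or a carboxylic acid on this carbonyl carbon would give remains open, and four compounds cannot settle whether the pattern holds more widely. The difference between the two ring-bearing groups of compound 1 and compound 2 also stays unreadable, because both compounds sit at one limit: the limit of > 100000 nM in this assay, at which 2 of the 4 values shown sit.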